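The compounds below may be only part of what the source reports. "The series", "measured", "known", "first", "only" and "open" are said of these compounds alone.

Compound 1 `Cc1nc(-c2ccccc2)sc1COc1ccc2c(c1)OCC2CC(=O)O`: 54.8%
Compound 2 `COc1ccc(-c2nc(C)c(COc3ccc4c(c3)OCC4CC(=O)O)s2)cc1`: 46.8%
Compound 3 `COc1cc(OC)cc(-c2nc(C)c(COc3ccc4c(c3)OCC4CC(=O)O)s2)c1`: 17.5%

In a functional assay on CHO cells for agonist activity at Free fatty acid receptor 1 (Homo sapiens), read by FLIPR and calcium flux, tested at 100 nM (a lower number here means a weaker effect, a higher number a stronger effect of the compound at the concentration tested), compound 1 gives 54.8%, compound 2 gives 46.8% and compound 3 gives 17.5%. The change methoxy in place of hydrogen on an aromatic carbon makes the step of a number 8 percentage points lower from compound 1 to compound 2 (within the scatter). The two cores differ by 3,5-dimethoxyphenyl in place of phenyl on an aromatic carbon, which makes the step of a number 37.3 percentage points lower from compound 1 to compound 3 (beyond the scatter); the step of a number 29.3 percentage points lower from compound 2 to compound 3 (beyond the scatter) also lies beyond the scatter. Compound 4 `COc1cc(-c2nc(C)c(COc3ccc4c(c3)OCC4CC(=O)O)s2)cc(OC)c1OC` is not yet measured. It differs from compound 3 by methoxy in place of hydrogen on an aromatic carbon, the same kind of change as from compound 1 to compound 2, but the place differs: here the entering group is ortho to two methoxy groups and para to a large group, whereas in compound 2 it is only para to a large group. In this assay the expected step for compound 4 is a number 5.5 percentage points lower from compound 3 to compound 4 (within the scatter), set beside the earlier step of a number 8 percentage points lower from compound 1 to compound 2 (within the scatter). The value expected for compound 4 is 12%, with a range from 2% to 28%, because compound 3 already gives only 17.5%.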

Compound 4, a percentage reported as activity, at one concentration (the size of the read-out at that concentration, not a potency): 7.47%
Compound 4: middle estimate off by 4.5 percentage points, on the high side; the range from low to high includes it.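

In this assay, methoxy in place of hydrogen on an aromatic carbon gives a number 10 percentage points lower from compound 3 to compound 4 (within the scatter). Set beside the earlier case, the change shows no difference that can be told apart between the two cores: the same change on two cores in this assay, a number 8 percentage points lower (within the scatter) from compound 1 to compound 2 and a number 10 percentage points lower (within the scatter) from compound 3 to compound 4, 2 percentage points apart, within the scatter of two such steps. Going by these compounds alone, this does not show that the change has no effect, as both steps lie within the scatter, nor that it would read the same on any further core, as only two cores are compared and the entering group is ortho to two methoxy groups only in compound 4.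

The compounds shown leave open what a group other than methoxy, such as fluorine or an amine, would give at these places on the phenyl. They also leave open how a longer chain in place of the acetic acid side chain would read.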